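This account rests on a few compounds, and the source may have more. Where it says the series, first, only, none or still open, it means among the compounds named here.

Measured in a functional assay on MCF7 cells (Homo sapiens) for antiproliferative activity, read by MTT assay, with a stated time of 72 h; a lower number here means a stronger inhibitor, a higher number a weaker inhibitor:
- Compound 1 `CCCSc1nc(N/N=C(\C)c2ccccc2O)c2nnn(Cc3ccc(Cl)cc3)c2n1`: 42600 nM
- Compound 2 `CCCSc1nc(N/N=C/c2cccnc2)c2nnn(Cc3ccccc3)c2n1`: 58700 nM
- Compound 3 `C#CCSc1nc(N/N=C/c2ccc(N(C)C)cc2)c2nnn(Cc3ccccc3)c2n1`: > 64000 nM

Compound 2, at 58700 nM, lies within the usual scatter of compound 1, at 42600 nM, so these two values cannot be told apart. Compound 3 gives only a limit, > 64000 nM, and not a number.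

The next molecule is compound 4 `CCCSc1nc(N/N=C/c2ccccc2Cl)c2nnn(Cc3ccccc3)c2n1`. It is compound 2 with 2-chlorophenyl in place of pyridin-3-yl on a carbon with a double bond to nitrogen. Within the data shown here, no two measured compounds differ in one place only, so the data give no direct size for a change of this kind. The expectation therefore starts from compound 2 at 58700 nM, with no step beyond the scatter expected in this assay, in either direction. The estimated change is a 1.7-fold lower number from compound 2 to compound 4 (0.22 log units; within the scatter), which stays within the scatter. For compound 4 the expected value is 35000 nM, with an estimated range from 12000 nM to 70000 nM.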

Compound 4, half-maximal inhibitory concentration: 13800 nM
For compound 4 the middle estimate is 2.5-fold (0.40 log units) above the measured one, within the range that was stated.
By their numbers in this assay, from the lowest: compound 4; then compounds 1 and 2 (each within the scatter of the next). At a limit, above all of these: compound 3.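

Compound 2 and compound 4 are the only pair shown in this assay that differs in one place, so the data now give a size for a change on this carbon with a double bond to nitrogen: a 4.3-fold lower number from compound 2 to compound 4 (0.63 log units; beyond the scatter). Among these compounds, with 2-chlorophenyl in place of pyridin-3-yl, the number falls by more than the usual scatter, so this position does respond to the group it carries, something the earlier compounds could not show. Nothing measured here accounts for the size of this step.

The change removes a ring nitrogen and adds a chlorine at once, and this single pair cannot tell which of the two matters. From the compounds shown here alone, how a plain phenyl ring, or a ring carrying a methoxy group or a carboxylic acid, would read at this place stays open.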